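The source may hold more compounds than are shown below. What is called first, only, known or untested is meant among the compounds shown, and "the series" means these compounds.

Working notes on the series built around the shared core of compound 1 `Cc1ccc(S(=O)(=O)NCc2cn(C[C@H](O)[C@H]3OC(=O)C(OCc4ccccc4)=C3OCc3ccccc3)nn2)cc1`. Within the data shown here, in a functional assay on HepG2 cells (Homo sapiens) for antiproliferative activity, read by MTT assay, with a stated time of 72 h (on this read-out lower numbers stand for stronger inhibition and higher numbers for weaker inhibition), compound 1 gives 24900 nM, the only numerical reading among the three measured compounds. Compound 2 `CC(C)(C)OC(=O)N1CCN(C(=S)SCc2cn(C[C@H](O)[C@H]3OC(=O)C(OCc4ccccc4)=C3OCc3ccccc3)nn2)CC1` reaches only the limit of this assay, > 100000 nM. Compound 3 `COc1ccccc1-c1cn(C/C=C2\OC(=O)C(OCc3ccccc3)=C2OCc2ccccc2)nn1` likewise stops at the limit, > 100000 nM. Compound 1 thus stands alone with a measurable value, while the limit of > 100000 nM in this assay, at which 2 of the 3 values shown sit, covers the other two. Compound 4 `O=C1O[C@H]([C@@H](O)Cn2cc(C3CC3)nn2)C(OCc2ccccc2)=C1OCc1ccccc1` remains to be measured; it differs from compound 1 by cyclopropyl in place of (((4-methylphenyl)sulfonyl)amino)methyl on an aromatic carbon. Among the measured compounds shown here, no step between measured compounds offers guidance on direction. The step is expected to be a 1.2-fold higher number from compound 1 to compound 4 (0.08 log units; within the scatter), none beyond the scatter. Compound 4 is accordingly estimated at 30000 nM in this assay, within a range from 8000 nM to 100000 nM, with a fair chance that only a limit is returned.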

Compound 4, half-maximal inhibitory concentration: 38100 nM
For compound 4 the middle estimate is 1.3-fold (0.10 log units) below the measured one; the measured number falls inside the stated range.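

In this assay, among these compounds, cyclopropyl in place of (((4-methylphenyl)sulfonyl)amino)methyl gives a 1.5-fold higher number from compound 1 to compound 4 (0.18 log units; within the scatter) on this aromatic carbon, the first readable step. A group of 12 heavy atoms carrying a six-membered aromatic ring and 1 hydrogen-bond donor and a group of 3 heavy atoms thus read alike at this position, in this one pair. Nothing shown accounts for this outcome.

From the compounds shown here alone, whether an amine or a carboxylic acid on this aromatic carbon would move the number beyond the scatter remains open. The same holds for a longer alkyl chain.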